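This account rests on a few compounds, and the source may have more. Where it says the series, first, only, none or still open, it means among the compounds named here.

Within the data shown here, in a functional assay on KBVIN cells (Homo sapiens) for antiproliferative activity, read by sulforhodamine B assay, with a stated time of 3 days (on this read-out higher numbers stand for weaker inhibition of growth and lower numbers for stronger inhibition of growth), compound 1 (`O=C(c1cccc(Nc2ncc(F)c(Nc3ccc(F)cc3)n2)c1)N1CCCCC1`) gives 13800 nM, and this is the only true number available so far. Compound 2 (`CN(C)c1ccc(C(=O)Nc2cccc(Nc3ncc(F)c(Nc4ccc(F)cc4)n3)c2)cc1`) is reported as > 10000 nM, which is a limit of the assay and not a number. Among the measured compounds shown here, no measured pair of compounds differs in one place, so the series offers no direct guide to the size of any structural step.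

The next compound to read is compound 3 (`O=C(Nc1cc(Cl)cc(Cl)c1)c1cccc(Nc2ncc(F)c(Nc3ccc(F)cc3)n2)c1`), which keeps the core of compound 1 and changes only the group on the carbonyl carbon: (3,5-dichlorophenyl)amino in place of piperidin-1-yl on a carbonyl carbon. In words, (3,5-dichlorophenyl)amino stands in place of piperidin-1-yl on a carbonyl carbon.

For the measured compounds named here, with no measured step to lean on, the expectation is tentative and starts from compound 1 at 13800 nM. A modest move toward stronger inhibition of growth is expected, only slightly beyond the usual scatter, and a result within the scatter would not surprise. The estimated step is a 2.3-fold lower number from compound 1 to compound 3 (0.36 log units; beyond the scatter). For compound 3 the expected value in this assay is 6000 nM, with an estimated range of 1500 nM to 20000 nM.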

Compound 3, concentration for 50% growth inhibition: 20700 nM
Compound 3: middle estimate off by 3.5-fold (0.54 log units), on the low side, and the stated range ends below it.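

In this assay, among these compounds, the first measured step on this carbonyl carbon is a 1.5-fold higher number from compound 1 to compound 3 (0.18 log units; within the scatter), and compound 1 and compound 3 cannot be told apart on that evidence. This holds even though the change exchanges a non-aromatic ring for an aromatic ring of carbon only and brings in the amide hydrogen, so neither the piperidin-1-yl ring nor the (3,5-dichlorophenyl)amino group stands out here as a group that sets the read-out. Compound 2 is a limit and not a number, and it offers no comparison with the other compounds: the limit of > 10000 nM in this assay, at which 1 of the 3 values shown sits.

As far as these compounds go, it remains open whether any group on this carbonyl carbon can move the value beyond the scatter, for example morpholin-4-yl, a short open-chain amine such as dimethylamino, or a hydroxyl that turns the carbonyl into a carboxylic acid. A plain phenylamino group on the same carbon would also be needed to separate the part played by the two chlorines from that of the amide hydrogen and the aromatic ring, and the compounds shown do not settle that question.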